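From thiophen-3-yl to 2,5-dimethylthiophen-3-yl

The source may report more compounds than this note shows. Statements on the series, on what has been measured and on what is new or still open speak of the compounds shown alone.

In a functional assay on cells (Melanoma cell, Homo sapiens) for inhibition (a lower number here means a stronger inhibitor of growth, a higher number a weaker inhibitor of growth), compound 3 `N=C(N)N/N=C/c1c(-c2ccsc2)nc2sccn12` gives 31600 nM. That value lies within the scatter of compound 1 `Cc1cn2c(/C=N/Nc3ccccn3)c(-c3ccc(Cl)c([N+](=O)[O-])c3)nc2s1`, at 38000 nM, and of compound 2 `Cc1cn2c(/C=N/NC(=N)N)c(-c3ccsc3)nc2s1`, at 19500 nM, so compound 3 holds no distinct rank among them. Compound 4 `Cc1cc(-c2nc3sccn3c2/C=N/NC(=N)N)c(C)s1` carries 2,5-dimethylthiophen-3-yl in place of thiophen-3-yl on an aromatic carbon. Among the compounds with values here, only one measured step involves a methyl group, a 1.6-fold higher number from compound 2 to compound 3 (0.21 log units; within the scatter), and that methyl sits on the shared core rather than on the thiophen-3-yl group. Within the data shown here, no measured pair tests methyl groups on that group, so no step beyond the scatter is expected in this assay. The expected step is a 1.2-fold lower number from compound 3 to compound 4 (0.08 log units; within the scatter). Compound 4 is estimated at 26000 nM, with an expected range of 12000 nM to 56000 nM.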

Compound 4, concentration for total growth inhibition: 30900 nM
Compound 4: middle estimate off by 1.2-fold (0.07 log units), on the low side; low and high end bracket the measured number.
By their numbers in this assay, from the lowest: compounds 2, 4, 3 and 1 (each within the scatter of the next).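

In this assay, placing 2,5-dimethylthiophen-3-yl where thiophen-3-yl stood gives a 1.0-fold lower number from compound 3 to compound 4 (0.01 log units; within the scatter) and so cannot be told apart from no change at all. Within the data shown here, this is the first measured pair that tests methyl groups on this ring rather than on the shared core, and at this place their presence leaves no measurable mark. No measurement offers an explanation for this result. Still open, from the compounds shown here alone, is whether an amine or a carboxylic acid on this ring would give a step beyond the scatter. Going by these compounds, the effect of either methyl group alone also remains unknown.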